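Swapping the Distal Phenyl for Nitro in Compound 2

A few compounds are considered here, and "the series" means these few. Any claim that something is new, unique, unknown or untested is made for them only; others in the source may bear on it.

Compound 1 `O=C(N1CCC=C[C@@H]1Cc1ccccc1)n1cc(-c2ccc(-c3ccccc3)cc2)nn1` carries a phenyl on a saturated chain carbon of its core. In an assay on HEK293 cells for inhibition of Monoacylglycerol lipase ABHD6 (Homo sapiens), read by fluorescence (a higher number here means a weaker inhibitor, a lower number a stronger inhibitor), compound 1 gives 2.51 nM. Compound 2 `O=C(N1CCC=C[C@@H]1COCc1ccccc1)n1cc(-c2ccc(-c3ccccc3)cc2)nn1` has a benzyloxy in that place, and in this assay compound 2 gives 12.6 nM. Compound 3 `O=C(N1CCC=C[C@H]1COCc1ccccc1)n1cc(-c2ccc(-c3ccccc3)cc2)nn1` has the same atoms and bonds as compound 2 and differs only in configuration at a saturated ring carbon; in this assay compound 3 gives 100 nM. Among these three numbers compound 2 stands second highest: the change a 5.0-fold higher number from compound 1 to compound 2 (0.70 log units; beyond the scatter) and the change a 7.9-fold higher number from compound 2 to compound 3 (0.90 log units; beyond the scatter) are both modest and both beyond the scatter. The second of them rests on (the fact that compounds 2 and 3 differ only in the configuration as drawn).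

Compound 4 `O=C(N1CCC=C[C@@H]1COCc1ccccc1)n1cc(-c2ccc([N+](=O)[O-])cc2)nn1` is not yet measured. It differs from compound 2 by nitro in place of phenyl on an aromatic carbon. Neither measured step touches this part of the molecule: one altered the group on the saturated chain carbon, the other the configuration at the ring carbon, so neither shows how the far end of the core tolerates change. Both measured steps were modest, and a step of similar modest size toward a higher number is expected here, with wide uncertainty. For compound 4 in this assay the expected value is 40 nM, with a range from 8 nM to 200 nM. This estimate corresponds to the expected step of a 3.2-fold higher number from compound 2 to compound 4 (0.50 log units; beyond the scatter).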

Compound 4, half-maximal inhibitory concentration: 31.6 nM
Compound 4: the middle estimate sits 1.3-fold (0.10 log units) above what was measured, and the stated range covers the measured number.
By their numbers in this assay, from the lowest: compound 1; then compound 2; then compound 4; then compound 3.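

In this assay, the change at this position is a 2.5-fold higher number from compound 2 to compound 4 (0.40 log units; beyond the scatter), which gives the first view of how this end of the molecule tolerates change. Replacing the phenyl, with its six carbons and one aromatic ring, by a nitro group of three heavy atoms and no ring weakens inhibition measurably but does not abolish it: compound 4 still gives 31.6 nM, so the phenyl is not essential for activity in this pair. The data shown offer no explanation for the size of this step.

This single swap removes a ring and adds two hydrogen-bond acceptors at once, so it cannot show which of these differences matters, or whether either does. It also leaves open how a smaller or differently built group at this place, such as an amine, a carboxylic acid or a methoxy group, would compare, and whether the nitro swap would give a similar step with the phenyl-bearing side chain of compound 1 or the opposite configuration of compound 3.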